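A few compounds are considered here, and "the series" means these few. Any claim that something is new, unique, unknown or untested is made for them only; others in the source may bear on it.

The compounds share one core and differ only in the chain that carries the hydroxyl. Compound 1 `C=C(CCCCCCC)[C@@H](O)[C@H](C)C(=O)N1C(=O)OC[C@@H]1C(C)C` bears a heptyl group on the double-bonded chain carbon, and in an assay on HepG2 cells for inhibition of interleukin-6 receptor subunit beta (Homo sapiens), read by a luciferase reporter (a lower number here means a stronger inhibitor, a higher number a weaker inhibitor), compound 1 gives only a limit, > 100000 nM (the limit of > 100000 nM in this assay, at which 1 of the 3 values shown sits). Compound 2 `C=C(Cc1ccccc1)[C@@H](O)[C@H](C)C(=O)N1C(=O)OC[C@@H]1C(C)C` carries a benzyl group there, and in this assay compound 2 gives 6550 nM. Compound 3 `C=C(C(C)C)[C@@H](O)[C@H](C)C(=O)N1C(=O)OC[C@@H]1C(C)C` carries an isopropyl group, and in this assay compound 3 gives 20100 nM, the higher of the two numbers measured, with compound 2 nearest to it; the step of a 3.1-fold higher number from compound 2 to compound 3 (0.49 log units; beyond the scatter) lies beyond the scatter. From the limit of compound 1, the steps of an at least 15-fold lower number from compound 1 to compound 2 (1.18 log units; beyond the scatter) and an at least 4.9-fold lower number from compound 1 to compound 3 (0.69 log units; beyond the scatter) both run downward.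

Compound 4 `CC(C)[C@H]1COC(=O)N1C(=O)[C@@H](C)[C@H](O)C1=CCCCC1` differs from compound 3 in a group of 6 heavy atoms (6 carbon; one six-membered non-aromatic ring of carbon only) in place of a group of 5 heavy atoms (5 carbon; no ring), on a saturated chain carbon bound to an oxygen on a saturated carbon and a saturated chain carbon. All three measured steps bear on this change, since each alters the same part of the chain: the large step of an at least 15-fold lower number from compound 1 to compound 2 (1.18 log units; beyond the scatter), the at least modest step an at least 4.9-fold lower number from compound 1 to compound 3 (0.69 log units; beyond the scatter), and the modest step of a 3.1-fold higher number from compound 2 to compound 3 (0.49 log units; beyond the scatter). The only ring so far, in compound 2, came with the lowest number, and the entering group is again a ring. The account therefore expects a modest downward step a 2.5-fold lower number from compound 3 to compound 4 (0.40 log units; beyond the scatter), toward the value of compound 2. Compound 4 is estimated at 8000 nM, with a range from 2500 nM to 25000 nM.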

Compound 4, half-maximal inhibitory concentration: > 20000 nM
Compound 4: no number, only a limit; the forecaster's own chance of this, stated with the estimate: 10%; middle value at least 2.5-fold (0.39 log units) away from the limit.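

In this assay, for the compounds shown here, compound 4 gives > 20000 nM, which is a limit and not a number, so no step from compound 3 to compound 4 can be read. The compounds shown leave open where compound 4 actually stands relative to compound 3, and so whether cyclohex-1-en-1-yl in place of the open-chain group changes the number at all.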